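Swapping an Aryl Group for Cyclopropyl: Expected Cytotoxicity

The source may report more compounds than this note shows. Statements on the series, on what has been measured and on what is new or still open speak of the compounds shown alone.

Compound 1 `CCOC(=O)c1oc2nc(-c3ccccc3)cc(C(F)(F)F)c2c1N` and compound 2 `COc1ccc(-c2cc(C(F)(F)F)c3c(N)c(C(N)=O)sc3n2)cc1` share a fused core carrying a trifluoromethyl group and an amine. In an ADME assay on Huh-7 cells (Homo sapiens) for cytotoxicity, read by MTT assay, with a stated time of 72 h (on this read-out higher numbers stand for lower toxicity in this test and lower numbers for higher toxicity in this test), the result for compound 1 is a limit of the test rather than a number, > 20000 nM. Within the data shown here, compound 2 is the only compound with an actual number in this assay, where compound 2 gives 46400 nM. Compound 3 `NC(=O)c1sc2nc(C3CC3)cc(C(F)(F)F)c2c1N` differs from compound 2 by cyclopropyl in place of 4-methoxyphenyl on an aromatic carbon. Among the measured compounds shown here, with no measured pair of this kind to lean on, the step from compound 2 to compound 3 in this assay is expected to stay within the scatter, a 1.1-fold higher number from compound 2 to compound 3 (0.03 log units; within the scatter). Compound 3 is therefore estimated at 50000 nM, between 20000 nM and 130000 nM.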

Compound 3, half-maximal cytotoxic concentration: > 20000 nM
Compound 3 was reported as a limit (the forecaster's own chance of this, stated with the estimate: 40%); the middle value is on the limit's open side.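

The step from compound 2 to compound 3 cannot be read, because compound 3 is reported only as a limit: the limit of > 20000 nM in this assay, at which 2 of the 3 values shown sit.

The compounds shown leave open whether cyclopropyl in place of 4-methoxyphenyl shifts the number in this assay at all, and in which direction.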